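The compounds below may be only part of what the source reports. "The series", "measured", "known", "first", "only" and "open" are said of these compounds alone.

In a toxicity assay on HepG2 2.2.15 cells (Homo sapiens) for cytotoxicity, read by CellTiter-Glo (a higher number here means that more compound is tolerated, a lower number that less compound is tolerated), compound 1 `O=C1OC(c2ccccc2)CN1c1cnn2c1CN(C(=O)Nc1cc(F)c(F)c(F)c1)C(C1CC1)C2` gives 7410 nM, the higher of the two exact numbers available. Compound 3 `O=C1OC(c2ccc(F)cc2)CN1c1cnn2c1CN(C(=O)Nc1cc(F)c(F)c(F)c1)C(C1CC1)C2` gives 3560 nM. Compound 2 `CC1CCn2ncc(N3CC(c4ccccc4)CC3=O)c2CN1C(=O)Nc1cc(F)c(F)c(F)c1` is reported only as a limit, > 2000 nM.

Compound 4 `O=C1CC(c2cnco2)CN1c1cnn2c1CN(C(=O)Nc1cc(F)c(F)c(F)c1)C(C1CC1)C2` has not yet been measured. Its difference from compound 1 is 4-(1,3-oxazol-5-yl)-2-oxopyrrolidin-1-yl in place of 2-oxo-5-phenyl-1,3-oxazolidin-3-yl on an aromatic carbon. In words, 4-(1,3-oxazol-5-yl)-2-oxopyrrolidin-1-yl stands in place of 2-oxo-5-phenyl-1,3-oxazolidin-3-yl on an aromatic carbon, and the rest of the core of compound 1 is kept. The six-membered aromatic ring of carbon only therefore leaves, and a five-membered aromatic ring with 2 hetero atoms enters.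

For the measured compounds named here, only one measured step bears on this change, and only indirectly: a 2.1-fold lower number from compound 1 to compound 3 (0.32 log units; beyond the scatter). That step is modest, and it alters the aromatic ring that leaves here rather than removing it. Going by the values given here, no measured step exchanges the whole group, so the direction rests on this single comparison and remains uncertain. A modest move toward a higher number is expected, and the estimated step is a 2.2-fold higher number from compound 1 to compound 4 (0.33 log units; beyond the scatter). For compound 4, the estimated value is 16000 nM, with an expected range from 5000 nM to 50000 nM.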

Compound 4, half-maximal cytotoxic concentration: 139000 nM
Compound 4: middle estimate off by 8.7-fold (0.94 log units), on the low side, outside the stated range (above it).
By their numbers in this assay, from the lowest: compound 3; then compound 1; then compound 4.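

The exchange of 2-oxo-5-phenyl-1,3-oxazolidin-3-yl for 4-(1,3-oxazol-5-yl)-2-oxopyrrolidin-1-yl in this assay gives a 19-fold higher number from compound 1 to compound 4 (1.27 log units; beyond the scatter), which shows that the number responds strongly to the group held on this aromatic carbon of the five-membered aromatic ring with 2 nitrogen. For the compounds shown here, the only earlier step, a 2.1-fold lower number from compound 1 to compound 3 (0.32 log units; beyond the scatter), altered the six-membered aromatic ring while keeping the rest of the group, so it showed a modest move in the opposite direction, whereas exchanging the whole group produces a large move toward more compound being tolerated. The values shown give no reason for the size of this step, and nothing measured here connects it to any property of either group.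

The change replaces both the non-aromatic ring and the aromatic ring in a single step, so the compounds shown leave open how much of the rise belongs to each of the two. Also open, on these data alone, is whether a pyridine or a thiazole carried on the 2-oxopyrrolidin-1-yl ring would give a number close to that of compound 4 or one closer to that of compound 1.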